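Exchanging the Aryl on the Sulfonyl: Compound 3 to Compound 4

The compounds below may be only part of what the source reports. "The series", "measured", "known", "first", "only" and "open" are said of these compounds alone.

Compound 1 `COc1ccc(-c2cc(=O)c3c(OC)cc(OC)cc3n2C)cc1` gives 68000 nM in an ADME assay on BJ cells (Homo sapiens) for antiproliferative activity, with a stated time of 72 h; on this read-out higher numbers stand for an effect only at larger amounts of compound and lower numbers for an effect already at smaller amounts.
Compound 2 `COc1ccc(-c2[nH]c3cc(OC)cc(OC)c3c(=O)c2I)cc1` reaches only a limit of this assay, > 86200 nM.
Compound 3 `COc1ccc(-c2cc(=O)c3c(OC)cc(OC)cc3n2S(=O)(=O)c2ccc(C=O)cc2)cc1` reaches only a limit of this assay, > 34400 nM.

Compound 3 therefore stands at a limit, not at a number, and so does compound 2; compound 1 alone has a measured value. Among the measured compounds shown here, the only one-place step, a step that the limit leaves unreadable from compound 1 to compound 3, cannot be read because of the limit of > 34400 nM in this assay, at which 1 of the 3 values shown sits. Compound 4 `COc1ccc(-c2cc(=O)c3c(OC)cc(OC)cc3n2S(=O)(=O)c2cc(Cl)cc(Cl)c2O)cc1` differs from compound 3 in one place: 3,5-dichloro-2-hydroxyphenyl in place of 4-formylphenyl on a sulfonyl sulfur. For the measured compounds named here, no measured step touches the group on the sulfonyl sulfur, so nothing among the measured compounds bears directly on this change, and compound 3 gives no numerical anchor. Compound 4 is therefore expected to sit near 40000 nM, between 10000 nM and 120000 nM, with a fair chance of again reaching only a limit. The step that the limit leaves unreadable from compound 3 to compound 4 that this estimate implies is expected to lie within the scatter of this assay.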

Compound 4, half-maximal effective concentration: > 37900 nM
Compound 4: only a limit was reported; the forecaster's own chance of this, stated with the estimate: 55%; the middle value lies beyond the limit too.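

In this assay compound 4 reaches only a limit, > 37900 nM. Among the compounds shown here, compound 3 also stands only at a limit, > 34400 nM, so no step between these two compounds can be read. On these data alone, what stays open is where compound 3 and compound 4 actually lie on this read-out, and so whether exchanging the group on the sulfonyl sulfur changes anything.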